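From pyridin-2-yl to 4-methylphenyl on the chain carbon

A few compounds are considered here, and "the series" means these few. Any claim that something is new, unique, unknown or untested is made for them only; others in the source may bear on it.

Measured in a toxicity assay on CHO cells (Cricetulus griseus) for cytotoxicity, read by MTT assay, with a stated time of 48 h; on this read-out higher numbers stand for weaker inhibition and lower numbers for stronger inhibition:
- compound 1 `COc1ccc(/C=C2\S/C(=N\c3ccccc3)N(Cc3ccco3)C2=O)cc1OC`: > 400000 nM (a limit)
- compound 2 `O=C1/C(=C/c2ccc(O)cc2)S/C(=N\c2ccccc2)N1Cc1ccco1`: 400000 nM
- compound 3 `O=C1/C(=C/c2ccccn2)S/C(=N\c2ccccc2)N1Cc1ccco1`: > 400000 nM (a limit)

Compound 3 has no exact number, and its entry of > 400000 nM is a limit. Compound 1 and compound 3 both stand at the limit of > 400000 nM in this assay, at which 2 of the 3 values shown sit. Compound 2 alone has a number, 400000 nM.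

The next compound is compound 4 `Cc1ccc(/C=C2\S/C(=N\c3ccccc3)N(Cc3ccco3)C2=O)cc1`. Its difference from compound 3 is 4-methylphenyl in place of pyridin-2-yl on a double-bonded chain carbon bound to a double-bonded ring carbon.

Three measured steps change the group at this same place: a number no higher from compound 1 to compound 2 (the limit leaves the size open), a step that the two limits leave unreadable from compound 1 to compound 3 and a number no lower from compound 2 to compound 3 (the limit leaves the size open). None of them has a readable size, so they give no measure of how far such a change can move the result. They do show that three different groups at this place leave the results at or against the same limit. Among the compounds with values here, with compound 2 at 400000 nM as the only number, no step beyond the scatter is expected in this assay. A further limit is the likeliest report. The expected step is a number no higher from compound 3 to compound 4 (the limit leaves the size open). Compound 4 is estimated at 400000 nM, with an expected range of 200000 nM to 800000 nM.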

Compound 4, half-maximal inhibitory concentration: 421000 nM
Compound 4: the middle estimate sits 1.1-fold (0.02 log units) below what was measured; the range from low to high includes it.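

In this assay, within the data shown here, the exchange of hydroxy for methyl on an aromatic carbon gives the first step of readable size among the groups on the double-bonded chain carbon: a 1.1-fold higher number from compound 2 to compound 4 (0.02 log units; within the scatter). The earlier compounds shown here showed only that the results sat at or against one limit, whereas compound 2 and compound 4 now give a comparison between two actual numbers, and they lie within the scatter of each other, so this change leaves no measurable mark on the result. The steps to compound 4 from compound 1 and from compound 3 cannot be read, because those two compounds carry limits and not numbers: the limit of > 400000 nM in this assay, at which 2 of the 4 values shown sit.

The compounds shown leave open whether any group on the chain carbon can bring the number clearly lower in this assay, for example a phenyl ring bearing an amine or a carboxylic acid. From the compounds shown here alone, they also say nothing about changes elsewhere on the shared core, so it remains unknown whether the flat result belongs to this position alone or to the whole series.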